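The source may hold more compounds than are shown below. What is called first, only, known or untested is meant among the compounds shown, and "the series" means these compounds.

In a functional assay on HCT-116 cells (Homo sapiens) for inhibition, read by sulforhodamine B assay, with a stated time of 48 h (a higher number here means a weaker inhibitor of growth, a lower number a stronger inhibitor of growth), three compounds sharing one core have been measured. Compound 1 `O=C(Nc1cccc(-n2cc(-c3ccncc3)c(-c3ccc(Cl)c(O)c3)n2)c1)Nc1ccc(Cl)c(Cl)c1` gives 1190 nM, compound 2 `O=C(Nc1cccc(-n2cc(-c3ccncc3)c(-c3ccc(Cl)c(O)c3)n2)c1)Nc1cc(C(F)(F)F)cc(C(F)(F)F)c1` gives 428 nM, and compound 3 `COc1cc(-c2nn(-c3cccc(NC(=O)Nc4cccc(C(F)(F)F)c4)c3)cc2-c2ccncc2)ccc1Cl` gives 900 nM. Among these three numbers compound 3 stands second highest: its nearest neighbour is compound 1, whose number lies within the scatter of it, and its furthest is compound 2, whose lower number lies beyond the scatter.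

The account now follows the step from compound 3 to the as yet unmeasured compound 4 `O=C(Nc1cccc(-n2cc(-c3ccncc3)c(-c3ccc(Cl)c(O)c3)n2)c1)Nc1cccc(C(F)(F)F)c1`. The difference between the two is small: hydrogen in place of methyl on an oxygen on an aromatic ring. Read one bond further out, this is methoxy to hydroxy, so that the 4-chloro-3-methoxyphenyl of compound 3 becomes the 4-chloro-3-hydroxyphenyl that compounds 1 and 2 already carry.

Within the data shown here, no measured pair in this set differs by that change alone, so its size is not known here. Compounds 1 and 2, which carry the hydroxy, span numbers on both sides of compound 3, and the expectation is that compound 4 sits close to compound 3, with a step of a 1.3-fold lower number from compound 3 to compound 4 (0.11 log units; within the scatter) that stays within the scatter or leans slightly toward a lower number. In this assay compound 4 is therefore estimated at 700 nM, with a likely range from 300 nM to 1600 nM.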

Compound 4, concentration for 50% growth inhibition: 1390 nM
The estimate for compound 4 lay 2.0-fold (0.30 log units) below the measured number; the range from low to high includes it.
By their numbers in this assay, from the lowest: compound 2; then compounds 3, 1 and 4 (each within the scatter of the next).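

In this assay, the step from methoxy to hydroxy on the 4-chloro-3-methoxyphenyl group can now be read alone, as a 1.5-fold higher number from compound 3 to compound 4 (0.19 log units; within the scatter), and at this position and on this background the exchange of methyl for hydrogen on the oxygen cannot be told apart from the scatter. With the hydroxy held in place, 3-(trifluoromethyl)phenyl in place of 3,4-dichlorophenyl on an amide-type nitrogen gives a 1.2-fold higher number from compound 1 to compound 4 (0.07 log units; within the scatter), which also stays within the scatter, whereas hydrogen in place of trifluoromethyl on an aromatic carbon gives a 3.2-fold higher number from compound 2 to compound 4 (0.51 log units; beyond the scatter), a modest step and the only one of these three to lie beyond the scatter. No measurement at hand offers a reason for the size of any of these steps.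

The compounds shown leave open what an ethoxy, a longer chain or an amine would give on this ring in place of the hydroxy. They also leave open whether methoxy to hydroxy would read the same with the two trifluoromethyl groups of compound 2 on the other side of the molecule.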